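A few compounds are considered here, and "the series" means these few. Any claim that something is new, unique, unknown or untested is made for them only; others in the source may bear on it.

Working notes on the thiosemicarbazone series.

Three compounds have numbers in a functional assay on HeLa cells (Homo sapiens) for antiproliferative activity, read by sulforhodamine B assay, with a stated time of 72 h; on this read-out lower numbers stand for stronger inhibition and higher numbers for weaker inhibition. Compound 1, `S=C(N/N=C/c1ccc2ccccc2n1)Nc1cccc(Cl)c1`, gives 52500 nM there. Compound 2, `CN(C)C(=S)N/N=C/c1nc2ccccc2s1`, gives 2100 nM in this assay, and compound 3, `CN(C)C(=S)N/N=C/c1cc2cccnc2s1`, gives 48400 nM. On these numbers compound 1 stands highest of the three: against compound 3 the gap is within the scatter of the method, so no order between the two can be read, while against compound 2 the gap is beyond the scatter, with compound 2 giving the lower number.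

Compound 4, `Fc1ccc(NC(=S)N/N=C/c2ccc3ccccc3n2)cc1`, has not yet been measured in this assay. It differs from compound 1 in one place: 4-fluorophenyl in place of 3-chlorophenyl on an amide-type nitrogen. The thiocarbonyl, the hydrazone linkage and the core of compound 1 are all kept.

Among the measured compounds shown here, no pair of measured compounds differing in one place is available, so the size of this step rests on no direct precedent. Compounds 1 and 3 share a high number with different cores, and the halophenyl change is small in count, so for a 1.1-fold lower number from compound 1 to compound 4 (0.02 log units; within the scatter) no step beyond the scatter is expected in either direction. The expected value for compound 4 in this assay is 50000 nM, with a range from 20000 nM to 150000 nM.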

Compound 4, half-maximal inhibitory concentration: 33200 nM
The estimate for compound 4 lay 1.5-fold (0.18 log units) above the measured number, within the range that was stated.
By their numbers in this assay, from the lowest: compound 2; then compounds 4, 3 and 1 (each within the scatter of the next).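

Among the compounds shown here, replacing 3-chlorophenyl with 4-fluorophenyl on an amide-type nitrogen gives, in this assay, a 1.6-fold lower number from compound 1 to compound 4 (0.20 log units; within the scatter), and this is the first direct step at any one position. For this pair, the change of group leaves the number within the usual spread of the method, so the high number of compound 1 is not specific to 3-chlorophenyl when set against this one replacement, although a single pair cannot show how far that holds for other groups at this position. No measurement is available that bears on why the step is this small.

Still open, as far as these compounds go, is whether any group at this position can move the number beyond the scatter, for example an unsubstituted phenyl, a phenyl carrying an amine or a carboxylic acid, or a longer alkyl chain in place of the ring. The identity of the halogen and its place on the ring change together in this one step, so their separate contributions cannot be told apart.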